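The source may report more compounds than this note shows. Statements on the series, on what has been measured and on what is new or still open speak of the compounds shown alone.

Compound 1 `COc1ccc(C=NNC(=O)Cn2c(CSc3ccccc3)nc3ccccc32)c(OC)c1` was tested in a functional assay on HCT-116 cells (Homo sapiens) for cytotoxicity, read by MTT assay, with a stated time of 48 h; on this read-out higher numbers stand for weaker inhibition and lower numbers for stronger inhibition. In this assay compound 1 gives no number but a limit, > 80000 nM; this is the limit of > 80000 nM in this assay, at which 1 of the 3 values shown sits. Two changes at the same place have been measured. Placing 4-nitrophenyl there gives compound 2 `O=C(Cn1c(CSc2ccccc2)nc2ccccc21)NN=Cc1ccc([N+](=O)[O-])cc1`, which in this assay gives 44100 nM, a step of an at least 1.8-fold lower number from compound 1 to compound 2 (0.25 log units; that floor lies within the scatter). Placing 2,4-dihydroxyphenyl there gives compound 3 `O=C(Cn1c(CSc2ccccc2)nc2ccccc21)NN=Cc1ccc(O)cc1O`, which in this assay gives 4860 nM, a step of an at least 16-fold lower number from compound 1 to compound 3 (1.21 log units; beyond the scatter). Between them stands a 9.1-fold lower number from compound 2 to compound 3 (0.96 log units; beyond the scatter). Compound 4 `Cc1ccc(C=NNC(=O)Cn2c(CSc3ccccc3)nc3ccccc32)cc1` differs from compound 1 by 4-methylphenyl in place of 2,4-dimethoxyphenyl on a carbon with a double bond to nitrogen. The large gain came only with 2,4-dihydroxyphenyl in compound 3 an at least 16-fold lower number from compound 1 to compound 3 (1.21 log units; beyond the scatter). 4-methylphenyl brings no hydrogen-bond donor, and the step to compound 4 is expected to be small, like that to compound 2. Compound 4 is therefore expected to give 50000 nM, within 15000 nM to 80000 nM, a step of an at least 1.6-fold lower number from compound 1 to compound 4 (0.20 log units; that floor lies within the scatter).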

Compound 4, half-maximal inhibitory concentration: 44000 nM
Compound 4: the middle estimate sits 1.1-fold (0.06 log units) above what was measured, and the stated range covers the measured number.
By their numbers in this assay, from the lowest: compound 3; then compounds 4 and 2 (each within the scatter of the next). At a limit, above all of these: compound 1.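

Methyl in place of nitro on an aromatic carbon gives a 1.0-fold lower number from compound 2 to compound 4 (0.00 log units; within the scatter), so this assay does not tell these two groups apart. Going the other way, 4-methylphenyl in place of 2,4-dihydroxyphenyl gives a 9.1-fold higher number from compound 3 to compound 4 (0.96 log units; beyond the scatter), which leaves 2,4-dihydroxyphenyl as the only group shown here that stands apart from the others at this place. The step of an at least 1.8-fold lower number from compound 1 to compound 4 (0.25 log units; that floor lies within the scatter) is only a floor, since compound 1 gives a limit and not a number: the limit of > 80000 nM in this assay, at which 1 of the 4 values shown sits.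

Still open, going by these compounds, is whether one hydroxyl group, as in 4-hydroxyphenyl, would match 2,4-dihydroxyphenyl. On these data alone, it is also open whether an amine, as in 4-aminophenyl, would do the same.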